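The compounds below may be only part of what the source reports. "The series", "measured", "known", "first", "only" and "open" are said of these compounds alone.

Compound 1 `CN(C)c1ncnc2c1c(-c1ccsc1)cn2[C@@H]1O[C@H](CO)[C@@H](O)[C@H]1O` gives 530 nM in a functional assay on K562 cells (Homo sapiens), read by MTT assay, with a stated time of 72 h; a lower number here means a stronger inhibitor, a higher number a weaker inhibitor. Compound 3 `C#Cc1cn([C@@H]2O[C@H](CO)[C@@H](O)[C@H]2O)c2ncnc(N(C)C)c12`, which carries ethynyl in place of thiophen-3-yl, gives 110 nM, so compound 1 has the higher of the two exact numbers. Compound 2 `CN(C)c1ncnc2c1c(-c1cc3ccccc3o1)cn2[C@@H]1O[C@H](CO)[C@@H](O)[C@H]1O`, with 1-benzofuran-2-yl in that place, is reported only as a limit of > 20000 nM.

Compound 4 `Cc1ncnc2c1c(-c1ccsc1)cn2[C@@H]1O[C@H](CO)[C@@H](O)[C@H]1O` keeps thiophen-3-yl and changes a different group on the shared core, with methyl in place of dimethylamino on an aromatic carbon. Within the data shown here, no measured step touches this place, so the evidence is only indirect. Swapping out thiophen-3-yl gives a 4.8-fold lower number from compound 1 to compound 3 (0.68 log units; beyond the scatter), and another swap at that same place gives an at least 37-fold higher number from compound 1 to compound 2 (1.57 log units; beyond the scatter). These steps show that a single replacement on the core can move the number modestly or a great deal, and in either direction. A modest step is therefore the working expectation. Among the measured compounds shown here, it leans tentatively towards a lower number, since the only step between two exact values, a 4.8-fold lower number from compound 1 to compound 3 (0.68 log units; beyond the scatter), went that way. The expected change in this assay is a 2.1-fold lower number from compound 1 to compound 4 (0.33 log units; beyond the scatter). Compound 4 is estimated at 250 nM, with an expected range of 40 nM to 2000 nM.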

Compound 4, half-maximal inhibitory concentration: 320 nM
Estimate against measurement, compound 4: 1.3-fold (0.11 log units) below, and the stated range covers the measured number.
By their numbers in this assay, from the lowest: compound 3; then compounds 4 and 1 (each within the scatter of the next). At a limit, above all of these: compound 2.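

Among these compounds, this is the first measured step at this place, the aromatic carbon next to the ring nitrogen. In this assay, methyl in place of dimethylamino gives a 1.7-fold lower number from compound 1 to compound 4 (0.22 log units; within the scatter), so with thiophen-3-yl kept, the two groups cannot be told apart in this read-out, even though methyl has a single heavy atom and no nitrogen while dimethylamino has three heavy atoms, including a nitrogen. The data shown offer no measured property that explains why this exchange leaves the number within the scatter.

This single pair does not show how far the position tolerates change, and a methoxy group, a primary amine or a longer chain such as propyl could give a very different number from either methyl or dimethylamino. It also leaves open whether methyl in place of dimethylamino would be just as quiet with another group at the thiophen-3-yl place, such as the ethynyl of compound 3 or the 1-benzofuran-2-yl of compound 2.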